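Moving the methoxy pattern on the anilino ring

This account rests on a few compounds, and the source may have more. Where it says the series, first, only, none or still open, it means among the compounds named here.

Compound 1 `FC(F)(F)c1ccc(CSc2nc(Nc3cccc(C(F)(F)F)c3)c3ccccc3n2)cc1`: 11700 nM
Compound 2 `COc1ccc(Nc2nc(SCc3ccc(C(F)(F)F)cc3)nc3ccccc23)c(OC)c1`: > 50000 nM

In a functional assay on HGC-27 cells (Homo sapiens) for cytotoxicity, read by MTT assay, with a stated time of 72 h (a higher number here means a weaker inhibitor, a lower number a stronger inhibitor), compound 1 gives 11700 nM. For compound 2 this assay reports only a limit, > 50000 nM, so compound 2 stands at the weak end of what is shown, with the step of an at least 4.2-fold higher number from compound 1 to compound 2 (0.63 log units; beyond the scatter) resting on that limit (the limit of > 50000 nM in this assay, at which 1 of the 2 values shown sits). Compound 3 `COc1ccc(Nc2nc(SCc3ccc(C(F)(F)F)cc3)nc3ccccc23)cc1OC` differs from compound 2 by 3,4-dimethoxyphenyl in place of 2,4-dimethoxyphenyl on a nitrogen on an aromatic ring. Among the compounds with values here, no measured step follows this rearrangement; the only measured step concerns a different group on the same nitrogen. Compound 3 is therefore expected to remain weak, an estimated at least 1.2-fold lower number from compound 2 to compound 3 (0.09 log units; that floor lies within the scatter). The estimated value of compound 3 is 40000 nM, ranging from 10000 nM to 150000 nM.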

Compound 3, half-maximal inhibitory concentration: 17900 nM
The estimate for compound 3 lay 2.2-fold (0.35 log units) above the measured number, and the stated range covers the measured number.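

With the same atoms joined differently, 3,4-dimethoxyphenyl in place of 2,4-dimethoxyphenyl on the nitrogen gives an at least 2.7-fold lower number from compound 2 to compound 3 (0.44 log units; beyond the scatter) in this assay, so the weak reading of compound 2 is not shared by every dimethoxyphenyl group at this place. That step rests on a limit for compound 2, not a number: the limit of > 50000 nM in this assay, at which 1 of the 3 values shown sits. Replacing 3-(trifluoromethyl)phenyl with 3,4-dimethoxyphenyl gives a 1.5-fold higher number from compound 1 to compound 3 (0.18 log units; within the scatter), so this assay does not separate these two groups. The compounds shown leave open how a single methoxy group, a hydroxyl group or an amine on this ring would read.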